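Aryl variation on the shared core: pyridin-4-yl to imidazolyl

A few compounds are considered here, and "the series" means these few. Any claim that something is new, unique, unknown or untested is made for them only; others in the source may bear on it.

Compound 1 `Cc1ccncc1-c1ncnc2c1cnn2CCN1CCCCC1`, compound 2 `c1ccc(-c2ncnc3c2cnn3CCN2CCCCC2)nc1` and compound 3 `c1cc(-c2ncnc3c2cnn3CCN2CCCCC2)ccn1` share a core and differ only in the aromatic group attached to it. In an assay on HEK293 cells for displacement of a labelled ligand from Sigma non-opioid intracellular receptor 1 (Homo sapiens), read by scintillation counting, with a stated time of 120 min (a higher number here means a weaker inhibitor, a lower number a stronger inhibitor), compound 1 gives 707 nM, compound 2 gives 634 nM and compound 3 gives 1720 nM. Compound 3 stands with the highest number of the three: the step of a 2.4-fold higher number from compound 1 to compound 3 (0.39 log units; beyond the scatter) and the step of a 2.7-fold higher number from compound 2 to compound 3 (0.43 log units; beyond the scatter) are both beyond the scatter, while the step of a 1.1-fold lower number from compound 1 to compound 2 (0.05 log units; within the scatter) is within it.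

Compound 4 `Cn1cnc(-c2ncnc3c2cnn3CCN2CCCCC2)c1` follows from compound 3 by the change (1-methyl-1H-imidazol-4-yl in place of pyridin-4-yl on an aromatic carbon). For the measured compounds named here, no measured step swaps a six-membered group for a five-membered one at this place. Going by the values given here, the steps that bear on the change are those from compound 1 and compound 2 to compound 3, which show that exchanging the aromatic group here moves this assay by modest amounts only. A step of similar modest size, without a firm direction, is therefore expected for compound 4, estimated as a 1.2-fold lower number from compound 3 to compound 4 (0.09 log units; within the scatter). Compound 4 is expected to give 1400 nM in this assay, with a range from 450 nM to 4500 nM.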

Compound 4, inhibition constant: 11800 nM
Compound 4: the middle estimate sits 8.4-fold (0.93 log units) below what was measured, outside the stated range (above it).
By their numbers in this assay, from the lowest: compounds 2 and 1 (each within the scatter of the next); then compound 3; then compound 4.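

In this assay, the 1-methyl-1H-imidazol-4-yl group brings a five-membered aromatic ring to this place, and the number rises against all three pyridinyl compounds: a 6.9-fold higher number from compound 3 to compound 4 (0.84 log units; beyond the scatter) and a 19-fold higher number from compound 2 to compound 4 (1.27 log units; beyond the scatter) and also a 17-fold higher number from compound 1 to compound 4 (1.22 log units; beyond the scatter). This position is therefore less tolerant than the pyridinyl compounds alone suggested, since each of these steps exceeds any step among those three compounds. No measurement shown here accounts for the rise.

Ring size, the number of ring hetero atoms and the methyl on the ring change together in this single step, so the compounds shown do not separate them. Going by these compounds, it remains open how a phenyl group, an unsubstituted imidazolyl or a thiazolyl group would read at this place.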